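A few compounds are considered here, and "the series" means these few. Any claim that something is new, unique, unknown or untested is made for them only; others in the source may bear on it.

For the measured compounds named here, the three compounds measured so far share one core, in which a saturated chain carbon bound to two aromatic carbons carries a branched side chain. Compound 1 `COc1cc(C(c2ccc(O)c(OC)c2)[C@@H](C)C(C)C)ccc1O` gives 20000 nM in a functional assay on HL-60 cells (Homo sapiens) for cytotoxicity, read by WST assay, with a stated time of 48 h; on this read-out lower numbers stand for stronger inhibition and higher numbers for weaker inhibition. Compound 2 `COC[C@@H](C)[C@@H](C)C(c1ccc(O)c(OC)c1)c1ccc(O)c(OC)c1` gives 85000 nM in this assay, and compound 3 `COc1cc(C(c2ccc(O)c(OC)c2)[C@H](CC(C)C)C(C)C)ccc1O` gives 9600 nM. Among these three numbers compound 1 stands second highest: the step of a 2.1-fold lower number from compound 1 to compound 3 (0.32 log units; beyond the scatter) is modest, and the step of a 4.3-fold higher number from compound 1 to compound 2 (0.63 log units; beyond the scatter) is larger. Compound 4 `CCCCC[C@H](C(C)C)C(c1ccc(O)c(OC)c1)c1ccc(O)c(OC)c1` has not yet been measured. It differs from compound 1 in one place: 1-isopropylhexyl in place of 1,2-dimethylpropyl on a saturated chain carbon bound to two aromatic carbons. Going by the values given here, two measured steps bear on this change. The step of a 2.1-fold lower number from compound 1 to compound 3 (0.32 log units; beyond the scatter) shows that a larger side chain at this carbon went with a lower number, and the step of an 8.9-fold lower number from compound 2 to compound 3 (0.95 log units; beyond the scatter) points the same way, with the side chain holding an oxygen giving the highest number of the three. The change to compound 4 likewise enlarges the side chain without adding any hydrogen-bond donor or acceptor, so a lowering beyond the scatter is expected. The expected step is a 2.5-fold lower number from compound 1 to compound 4 (0.40 log units; beyond the scatter). Compound 4 is therefore estimated at 8000 nM, with a range from 3000 nM to 25000 nM.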

Compound 4, half-maximal inhibitory concentration: 9600 nM
Compound 4: the middle estimate sits 1.2-fold (0.08 log units) below what was measured; measured number inside the range.
By their numbers in this assay, from the lowest: compounds 3 and 4 (each within the scatter of the next); then compound 1; then compound 2.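

In this assay, replacing 1,2-dimethylpropyl with 1-isopropylhexyl on the saturated chain carbon bound to two aromatic carbons gives a 2.1-fold lower number from compound 1 to compound 4 (0.32 log units; beyond the scatter), and replacing the side chain of compound 2 gives an 8.9-fold lower number from compound 2 to compound 4 (0.95 log units; beyond the scatter). These steps show that the lower number seen earlier with compound 3 is not tied to the 1-isopropyl-3-methylbutyl side chain alone, as a second all-carbon side chain gives steps of the same size. The direct comparison adds something new: butyl in place of isopropyl on a saturated chain carbon, three bonds along the chain from two aromatic carbons, gives no change at the digits printed from compound 3 to compound 4 (within the scatter), so this particular change at the end of the side chain has no visible effect on the read-out.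

The compounds shown leave open whether a longer chain, such as 1-isopropyldecyl, would give a different number, and whether a ring such as cyclohexyl would give a step like these. They also leave open how a side chain carrying an amine or a carboxylic acid would compare with the oxygen-holding side chain of compound 2. No measurement offered here explains why compound 3 and compound 4 give the same number.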